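Halogen Swap on the Piperazine Aryl Group in Mice

A few compounds are considered here, and "the series" means these few. Any claim that something is new, unique, unknown or untested is made for them only; others in the source may bear on it.

Three compounds have so far been measured in a functional assay on the whole organism with Mus musculus as the target; a lower number here means that less compound is needed, a higher number that more compound is needed for the effect:

compound 1, `O=c1oc2cccnc2n1CN1CCN(c2ccc(F)cc2)CC1`, gives 3.5 mg/kg.
compound 2, `Cc1ccc2oc(=O)n(CCN3CCN(c4ccccc4)CC3)c2n1`, gives only a limit of the assay, > 50 mg/kg.
compound 3, `COc1ccccc1N1CCN(CCn2c(=O)oc3cccnc32)CC1`, gives only a limit of the assay, > 50 mg/kg.

Within the data shown here, compound 1 is thus the only compound of the three with an actual number in this assay; the other two sit at the limit of > 50 mg/kg in this assay, at which 2 of the 3 values shown sit. Compounds 2 and 3 differ from compound 1 in more than one place. Among the measured compounds shown here, no single measured step connects any pair of them, and the set gives no direct guide to how a change on the aryl group attached to the piperazine ring moves the read-out.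

Compound 4, `O=c1oc2cccnc2n1CN1CCN(c2cccc(Cl)c2)CC1`, is not yet measured. It differs from compound 1 only as follows: 3-chlorophenyl in place of 4-fluorophenyl on an amine nitrogen in a ring. For the measured compounds named here, with no measured step of this kind available, the expectation must rest on compound 1 alone. The step of a 1.4-fold higher number from compound 1 to compound 4 (0.15 log units; within the scatter) is expected to be none beyond the usual scatter, perhaps a slight rise in dose. Compound 4 is therefore expected to give about 5 mg/kg in this assay, within a range from 1.5 mg/kg to 15 mg/kg.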

Compound 4, dose for half-maximal effect: 10.5 mg/kg
The estimate for compound 4 lay 2.1-fold (0.32 log units) below the measured number; low and high end bracket the measured number.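

Among these compounds, the change from 4-fluorophenyl to 3-chlorophenyl on the amine nitrogen in the ring gives the first measured step at this position: in this assay the read-out shows a 3.0-fold higher number from compound 1 to compound 4 (0.48 log units; beyond the scatter). The position is therefore not silent to a change on the aryl group, yet compound 4 still gives a real number, 10.5 mg/kg, and not a limit of the assay. The two groups match in heavy atoms, in their single aromatic ring of carbon only and in their hydrogen-bond donors and acceptors, and nothing measured here explains the step.

The change replaces the halogen and moves it on the phenyl ring in a single step, so these compounds cannot say which of the two accounts for the higher number, nor how a nitrile or a trifluoromethyl group on that ring would read out. On these data alone, compound 2 and compound 3 differ from compound 1 in more than one place, so they add no readable step to this comparison, and the effect of the linking chain between the shared core and the piperazine also stays open.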